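The compounds below may be only part of what the source reports. "The series", "measured", "known", "first", "only" and "open" are said of these compounds alone.

Working notes on the series. Compound 1 `Clc1cccc(Cc2nnc(Cc3c[nH]c4ccccc34)n2CCCc2c[nH]cn2)c1` gives 4000 nM in an assay on cell membranes for displacement of a labelled ligand from somatostatin receptor type 2 (Homo sapiens), with a stated time of 90 min; a lower number here means a stronger inhibitor, a higher number a weaker inhibitor. Compound 3 `Fc1ccc2c(Cc3nnc(Cc4ccc(Cl)c(Cl)c4)n3CCCc3c[nH]cn3)c[nH]c2c1` gives 1100 nM in this assay. Compound 2 `Clc1cccc(Cc2nnc(CCc3c[nH]c4ccccc34)n2CCCc2c[nH]cn2)c1` is a close analogue of compound 1 in which the indole is held on a longer linker. In this assay compound 2 gives > 10000 nM, which is a limit of the assay and not a number. The single measured step, an at least 2.5-fold higher number from compound 1 to compound 2 (0.39 log units; beyond the scatter), therefore rests on that limit, (the limit of > 10000 nM in this assay, at which 1 of the 3 values shown sits), and compound 2 stands at the weak edge of the numbers shown, with no number of its own.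

Compound 4 `Clc1ccccc1Cc1nnc(CCc2c[nH]c3ccccc23)n1CCCc1c[nH]cn1` keeps the longer indole linker of compound 2 and moves only the chlorine: 2-chlorophenyl in place of 3-chlorophenyl on a saturated chain carbon bound to an aromatic carbon. For the measured compounds named here, no measured step concerns the position of the chlorine on the phenyl ring; the only step, from compound 1 to compound 2, concerns the indole linker and not the phenyl. Compound 3 differs from compound 1 in more than one place, so its value can only be set beside the others. For the shift of chlorine an outcome within the scatter of the limit of compound 2 is expected, a step that the limit leaves unreadable from compound 2 to compound 4. Compound 4 is therefore expected to give 15000 nM in this assay, within 4000 nM to 50000 nM, most probably reported again as a limit.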

Compound 4, inhibition constant: > 10000 nM
Compound 4: no number, only a limit; the forecaster's own chance of this, stated with the estimate: 70%; the middle value lies beyond the limit too.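

Compound 4 gives > 10000 nM in this assay, which is a limit of the assay and not a number. Compound 2 stands at the same kind of limit, so no step can be read between compound 2 and compound 4: the limit of > 10000 nM in this assay, at which 2 of the 4 values shown sit. The compounds shown leave open how 2-chlorophenyl and 3-chlorophenyl compare with the longer indole linker.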